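A few compounds are considered here, and "the series" means these few. Any claim that something is new, unique, unknown or untested is made for them only; others in the source may bear on it.

Of the compounds shown here, two carry numbers so far. Compound 1 `Cc1nc(-c2c(F)cc(Cl)cc2-c2cnc(CNC(=O)N(C)O)c(F)c2)no1` gives 17 nM in a functional assay on IMR-90 cells for antagonist activity at B1 bradykinin receptor (Homo sapiens), read by calcium flux; a higher number here means a weaker inhibitor, a lower number a stronger inhibitor. Compound 2 `CCN(O)C(=O)NCc1ncc(-c2cc(Cl)cc(F)c2-c2nnn(C)n2)cc1F` gives 4.6 nM in this assay, the lower of the two numbers; its gap to compound 1 lies beyond the scatter, so compound 2 is the stronger inhibitor of the pair. Compound 3 `Cn1nnc(-c2c(F)cc(Cl)cc2-c2cnc(CNC(=O)N(O)C3CCC(F)(F)CC3)c(F)c2)n1` has not yet been measured. It differs from compound 2 by 4,4-difluorocyclohexyl in place of ethyl on an amide-type nitrogen. No measured pair in the set shows this change, so its size cannot be read from a shown step. For compound 3 the step in this assay is estimated as a 1.2-fold lower number from compound 2 to compound 3 (0.06 log units; within the scatter), not beyond the usual scatter and without a clear direction. Compound 3 is accordingly expected to give 4 nM in this assay, with a likely range from 1.2 nM to 14 nM.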

Compound 3, half-maximal inhibitory concentration: 0.19 nM
Estimate against measurement, compound 3: 21-fold (1.32 log units) above; measured number outside the range, below it.
By their numbers in this assay, from the lowest: compound 3; then compound 2; then compound 1.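

In this assay, 4,4-difluorocyclohexyl in place of ethyl on the amide-type nitrogen gives a 24-fold lower number from compound 2 to compound 3 (1.38 log units; beyond the scatter), a large step. This position, whose nitrogen also carries the carbonyl carbon and the oxygen, therefore accepts a six-membered non-aromatic ring, and its substituent can move the number far beyond the scatter, which compounds 1 and 2 alone could not show. Nothing on hand accounts for the size of this step.

For the compounds shown here, the single step does not separate the contribution of the ring from that of its two fluorine atoms; unsubstituted cyclohexyl and a longer open chain such as n-butyl would bear on that. On these data alone, whether the same change carries over to the core of compound 1 also remains open.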